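A Larger Aromatic Group on the Shared Core

This account rests on a few compounds, and the source may have more. Where it says the series, first, only, none or still open, it means among the compounds named here.

Three compounds have so far been measured in a functional assay on MCF7 cells (Homo sapiens) for inhibition, read by MTT assay, with a stated time of 24 h; a higher number here means a weaker inhibitor, a lower number a stronger inhibitor:
compound 1 `CCOC(=O)C1=Cc2ccccc2OC1(OCc1cc(-c2ccc(F)cc2F)no1)C(F)(F)F`: > 150000 nM
compound 2 `CCOC(=O)C1=Cc2ccccc2OC1(OCc1cc(-c2ccc(C)cc2)no1)C(F)(F)F`: > 150000 nM
compound 3 `CCOC(=O)C1=Cc2ccccc2OC1(OCc1cn(-c2cccc(OC)c2)nn1)C(F)(F)F`: > 150000 nM

Each of these values is a limit of the assay and not a number. Compound 2 stands at that limit, as do the two other values shown, so the limit of > 150000 nM in this assay, at which 3 of the 3 values shown sit, is all the evidence there is. For the measured compounds named here, the one measured step, a step that the two limits leave unreadable from compound 1 to compound 2, is therefore unreadable. Compound 4 `CCOC(=O)C1=Cc2ccccc2OC1(OCc1cc(-c2ccc3ccccc3c2)no1)C(F)(F)F` differs from compound 2 by naphthalen-2-yl in place of 4-methylphenyl on an aromatic carbon. Going by the values given here, no measured step bears readably on this change, so compound 4 is expected to remain at the limit, with a number no higher from compound 2 to compound 4 (the limit leaves the size open) expected to be no more than the scatter. Compound 4 is estimated at 150000 nM, between 50000 nM and 300000 nM.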

Compound 4, half-maximal inhibitory concentration: 65400 nM
Beside the measured number, compound 4's estimate is 2.3-fold (0.36 log units) above it; the measured number falls inside the stated range.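

In this assay, this aromatic carbon of the five-membered ring gives its first readable change: an at least 2.2-fold lower number from compound 2 to compound 4 (0.36 log units; beyond the scatter) with naphthalen-2-yl in place of 4-methylphenyl, and an at least 2.2-fold lower number from compound 1 to compound 4 (0.36 log units; beyond the scatter) with naphthalen-2-yl in place of 2,4-difluorophenyl. The aryl group at this position can therefore move a compound off the limit, which the other compounds shown do not do: the limit of > 150000 nM in this assay, at which 3 of the 4 values shown sit.

On these data alone, the true size of both steps stays open, since each starts from a limit. Also open, as far as these compounds go, is whether a quinolinyl group or a biphenyl group at this carbon would act like naphthalen-2-yl.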